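Anilino-thiazolyl chalcones: the anilino ring against cytotoxicity

The compounds below may be only part of what the source reports. "The series", "measured", "known", "first", "only" and "open" are said of these compounds alone.

Compound 1 `Cc1nc(Nc2ccc(Cl)cc2)sc1C(=O)/C=C/c1ccc(Cl)cc1`: in a functional assay on NCI-H460 cells (Homo sapiens) for cytotoxicity, read by MTT assay (on this read-out lower numbers stand for stronger inhibition and higher numbers for weaker inhibition), compound 1 gives only the assay limit > 25000 nM.
Compound 2 `Cc1nc(Nc2ccc(Cl)c(Cl)c2)sc1C(=O)/C=C/c1ccc(Cl)cc1`: in this assay compound 2 gives only the assay limit > 25000 nM.

Both measured compounds share the core of compound 1 and differ only in the anilino ring. Among the compounds with values here, the single measured step, a step that the two limits leave unreadable from compound 1 to compound 2, is a chloro in place of hydrogen on an aromatic carbon, and since both ends are limits its size cannot be read. Compound 2 therefore stands at the limit of this assay, and nothing more is known of it than that; the whole measured record is the limit of > 25000 nM in this assay, at which 2 of the 2 values shown sit.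

The next compound, compound 3 `Cc1cccc(Nc2nc(C)c(C(=O)/C=C/c3ccc(Cl)cc3)s2)c1`, changes the same ring again: 3-methylphenyl in place of 3,4-dichlorophenyl on a nitrogen on an aromatic ring. Within the data shown here, no measured step bears on a methyl for chloro exchange here, and the one step that touches this ring is unreadable, so no direction can be drawn from the data. With both neighbours at the limit, compound 3 is expected to sit near the limit as well, a step that the limit leaves unreadable from compound 2 to compound 3, and its value in this assay is estimated at 30000 nM, between 8000 nM and 100000 nM.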

Compound 3, half-maximal inhibitory concentration: > 25000 nM
Compound 3 ended at the assay's limit (the forecaster's own chance of this, stated with the estimate: 70%); the middle value does not contradict the limit.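

The steps from compound 1 to compound 3 and from compound 2 to compound 3 cannot be read, because all three compounds rest on the same assay limit: the limit of > 25000 nM in this assay, at which 3 of the 3 values shown sit.

The compounds shown leave open how 4-chlorophenyl, 3,4-dichlorophenyl and 3-methylphenyl rank against one another, and whether any anilino ring on the shared core gives a value short of the limit.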